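This account rests on a few compounds, and the source may have more. Where it says the series, first, only, none or still open, it means among the compounds named here.

Compound 1 `Cn1c(=O)cnn(CCCCN2CCN(c3ccccc3)CC2)c1=O` and compound 2 `Cn1c(=O)cnn(CCCCN2CCN(c3ccccc3F)CC2)c1=O` differ by fluoro in place of hydrogen on an aromatic carbon. In an assay for displacement of a labelled ligand from Adrenergic receptor alpha-1 (Homo sapiens) (on this read-out lower numbers stand for stronger inhibition and higher numbers for weaker inhibition), compound 1 gives 64 nM, while compound 2 gives 9.73 nM, so the fluoro brought a 6.6-fold lower number from compound 1 to compound 2 (0.82 log units; beyond the scatter). Compound 3 `Cn1c(=O)cnn(CCCN2CCN(c3ccccc3)CC2)c1=O` has a different core; how its core differs from that of compound 1 is not broken down here. In this assay compound 3 reaches only > 10000 nM, which is a limit of the assay and not a number (the limit of > 10000 nM in this assay, at which 1 of the 3 values shown sits). Compound 4 `Cn1c(=O)cnn(CCCN2CCN(c3ccccc3F)CC2)c1=O` is not yet measured and differs from compound 3 by fluoro in place of hydrogen on an aromatic carbon, the same change as between compound 1 and compound 2, at the same place. In this assay a step of about an at least 2.5-fold lower number from compound 3 to compound 4 (0.39 log units; beyond the scatter) is expected, resting on a 6.6-fold lower number from compound 1 to compound 2 (0.82 log units; beyond the scatter); as compound 3 sits at the limit, compound 4 may also give only a limit. Compound 4 is estimated at 4000 nM, between 800 nM and 20000 nM.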

Compound 4, inhibition constant: > 10000 nM
Compound 4 gave a limit, no number; the forecaster's own chance of this, stated with the estimate: 40%; middle value at least 2.5-fold (0.39 log units) from the limit.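

Compound 3 and compound 4 both stand at a limit in this assay, not at a number, so no step can be read between them: the limit of > 10000 nM in this assay, at which 2 of the 4 values shown sit.

The compounds shown leave open whether fluoro in place of hydrogen changes binding at all on the core of compound 3.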